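This account rests on a few compounds, and the source may have more. Where it says the series, first, only, none or still open, it means among the compounds named here.

In a physicochemical assay for solubility, read by HPLC, in phosphate buffer, with a stated time of 72 h, at pH 7.4 (a higher number here means a more soluble compound, a lower number a less soluble compound), compound 1 (`C[C@H](Nc1ncnc(N)c1C#N)c1nc2ccc(F)cc2n1-c1ccc(F)cc1`) gives 353000 nM and compound 2 (`C[C@H](Nc1ncnc(N)c1C#N)c1nc2ccc(F)cc2n1-c1cc(F)cc(F)c1`) gives 305000 nM so the two stand within the scatter of each other. Compound 3 (`C[C@H](Nc1ncnc(N)c1C#N)c1nc2ccc(F)cc2n1-c1ccccc1`) carries phenyl in place of 3,5-difluorophenyl on an aromatic nitrogen. Within the data shown here, the one measured step at this place (a 1.2-fold lower number from compound 1 to compound 2 (0.06 log units; within the scatter)) lies within the scatter, although both measured compounds keep fluorine on that ring. No step beyond the scatter is therefore expected in this assay for this change. The estimate amounts to an expected 1.1-fold higher number from compound 2 to compound 3 (0.06 log units; within the scatter) within the scatter. Compound 3 is estimated at 350000 nM with an expected range from 170000 nM to 700000 nM in this measurement.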

Compound 3, solubility: 374000 nM
Beside the measured number, compound 3's estimate is 1.1-fold (0.03 log units) below it, within the range that was stated.
By their numbers in this assay, from the lowest: compounds 2, 1 and 3 (each within the scatter of the next).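

In this assay the ring on the aromatic nitrogen now carries no fluorine at all, and the read-out stays within the scatter for phenyl in place of 3,5-difluorophenyl (a 1.2-fold higher number from compound 2 to compound 3 (0.09 log units; within the scatter)) and for hydrogen in place of fluoro (a 1.1-fold higher number from compound 1 to compound 3 (0.03 log units; within the scatter)). Neither one nor two fluorines on this ring separates these compounds in this read-out. No measurement at hand accounts for this. From the compounds shown here alone, whether an amine or a carboxylic acid on that ring would give a step beyond the scatter stays open, as does a longer chain in place of the ring on the aromatic nitrogen.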